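Urea series: hexyl for isopropyl, compound 2 to compound 4

The compounds below may be only part of what the source reports. "The series", "measured", "known", "first", "only" and "open" are said of these compounds alone.

Measured compounds in an ADME assay on the whole organism with Oryza sativa as the target, tested at 10 uM; a higher number here means a weaker effect of the compound at the concentration tested, a lower number a stronger effect:
Compound 1, `CC(C)c1ccc(NC(=O)N[C@H](C)c2ccccc2)cc1`, gives 49%.
Compound 2, `CC(C)c1ccc(NC(=O)N[C@@H](C)c2ccccc2)cc1`, gives 86%.
Compound 3, `C[C@H](NC(=O)Nc1ccccc1C(C)(C)C)c1ccccc1`, gives 100%.

Compound 2 holds the second highest of the three numbers. Its nearest neighbour is compound 3, whose number lies higher beyond the scatter; the furthest is compound 1, whose number lies lower beyond the scatter. For the measured compounds named here, the only single-point step among the measured compounds is a number 37 percentage points higher from compound 1 to compound 2 (beyond the scatter), which is large; it rests on the fact that compounds 1 and 2 differ only in the configuration as drawn and concerns configuration only.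

Compound 4, `CCCCCCc1ccc(NC(=O)N[C@@H](C)c2ccccc2)cc1`, differs from compound 2 by hexyl in place of isopropyl on an aromatic carbon. Going by the values given here, no measured step touches a change of this kind: the sole step is a change of configuration, and the change from compound 2 to compound 3 moves the same small group to another place on the ring and is not a single-point step. There is therefore no basis for expecting a step beyond the scatter in this assay in either direction, and the expectation is a number 1 percentage points lower from compound 2 to compound 4 (within the scatter). Compound 4 is thus estimated at 85%, with a range from 60% to 100%.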

Compound 4, a percentage reported as activity, at one concentration (the size of the read-out at that concentration, not a potency): 99%
For compound 4 the middle estimate is 14 percentage points below the measured one, within the range that was stated.
By their numbers in this assay, from the lowest: compound 1; then compound 2; then compounds 4 and 3 (each within the scatter of the next).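

In this assay, the position on the aromatic carbon para to a large group responds to a change of substituent and not only to configuration: hexyl in place of isopropyl gives a number 13 percentage points higher from compound 2 to compound 4 (beyond the scatter), a modest step. In the direction of this read-out, the longer chain goes with a weaker effect at the concentration tested, and this holds for the configuration of compound 2 alone. For the compounds shown here, nothing at hand accounts for this step, as the only available comparison concerns configuration and not this substituent.

As far as these compounds go, it remains open whether hexyl has a similar effect in the configuration of compound 1, which gives 49%. Going by these compounds alone, with only one step at this position, no trend with chain length can be drawn, and butyl, methoxy or a carboxylic acid there could each read differently.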